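The source may report more compounds than this note shows. Statements on the series, on what has been measured and on what is new or still open speak of the compounds shown alone.

Working notes on the series. Compound 1 `O=C(CN1CCN(c2cc3c(cc2F)c(=O)c(C(=O)O)cn3C2CC2)CC1)Nc1ccc(C(=O)/C=C/c2ccccc2Cl)cc1` gives 4.2% in an assay on isolated protein for inhibition of DNA topoisomerase 1 (Homo sapiens), with a stated time of 30 min, tested at 20 uM; a higher number here means a stronger effect of the compound at the concentration tested, a lower number a weaker effect. Among the compounds with values here, compound 2 `COc1ccc(/C=C/C(=O)c2ccc(NC(=O)CN3CCN(c4cc5c(cc4F)c(=O)c(C(=O)O)cn5C4CC4)CC3)cc2)cc1OC` gives 2.5% in this assay, the lower of the two numbers at hand, with compound 1 as its only neighbour; the sole measured step, a number 1.7 percentage points lower from compound 1 to compound 2 (within the scatter), is within the scatter, so the two aryl groups on the double-bonded chain carbon bound to a double-bonded chain carbon are not told apart by this assay.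

Compound 3 `O=C(CN1CCN(c2cc3c(cc2F)c(=O)c(C(=O)O)cn3C2CC2)CC1)Nc1ccc(C(=O)/C=C/c2cccc([N+](=O)[O-])c2)cc1` is not yet measured. It differs from compound 2 in the same place: 3-nitrophenyl in place of 3,4-dimethoxyphenyl on a double-bonded chain carbon bound to a double-bonded chain carbon. Within the data shown here, the one step that bears on this place, a number 1.7 percentage points lower from compound 1 to compound 2 (within the scatter), was small, so a further exchange of the aryl group is expected to give a step of a number 1.5 percentage points higher from compound 2 to compound 3 (within the scatter), nothing beyond the scatter, in either direction. Compound 3 is therefore estimated at 4%, within a range from -5% to 15%.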

Compound 3, a percentage reported as inhibition, at one concentration (the size of the read-out at that concentration, not a potency): 11.1%
Estimate against measurement, compound 3: 7.1 percentage points below, within the range that was stated.
By their numbers in this assay, from the lowest: compounds 2, 1 and 3 (each within the scatter of the next).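

With 3-nitrophenyl on a double-bonded chain carbon bound to a double-bonded chain carbon, a third aryl group can be compared at this place: in this assay the exchange gives a number 8.6 percentage points higher from compound 2 to compound 3 (within the scatter) and a number 6.9 percentage points higher from compound 1 to compound 3 (within the scatter), both within the scatter. The nitro group, a different kind of substituent from the chlorine and the two methoxy groups, therefore still does not separate the aryl groups in this read-out, and the three compounds remain a single level. No supporting measurement is available to explain these results.

The compounds shown leave open whether a group of another kind at this place, such as an aminophenyl group, a carboxylic acid on the phenyl ring or a pyridine ring, would give a step beyond the scatter. Also open, on these data alone, is whether a longer chain between the piperazine nitrogen and the amide would do so.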